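Cathepsin S series: amide substituent swap at the carbonyl

This account rests on a few compounds, and the source may have more. Where it says the series, first, only, none or still open, it means among the compounds named here.

Among the compounds with values here, compound 3 `N#CC1(NC(=O)[C@@H]2C[C@@H](S(=O)(=O)c3ccccc3)C[C@H]2C(=O)N2CCNCC2)CC1` gives 11 nM in an assay on isolated protein for inhibition of cathepsin S (Homo sapiens), read by fluorescence, with a stated time of 20 min (on this read-out higher numbers stand for weaker inhibition and lower numbers for stronger inhibition), the highest of the three numbers measured so far. Compound 1 `N#CC1(NC(=O)[C@@H]2C[C@@H](S(=O)(=O)c3ccccc3)C[C@H]2C(=O)N2CCOCC2)CC1` gives 0.7 nM, and compound 2 `N#CC1(NC(=O)[C@@H]2C[C@@H](S(=O)(=O)c3ccccc3)C[C@H]2C(=O)N2CCOCC2)CCC1` gives 4 nM. Compound 4 `N#CC1(NC(=O)[C@@H]2C[C@@H](S(=O)(=O)c3ccccc3)C[C@H]2C(=O)N2CC(O)C2)CC1` is not yet measured; it differs from compound 3 by 3-hydroxyazetidin-1-yl in place of piperazin-1-yl on a carbonyl carbon.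

Of the two measured steps, only a 16-fold higher number from compound 1 to compound 3 (1.20 log units; beyond the scatter) touches the same carbonyl substituent, and it was large. The other step, a 5.7-fold higher number from compound 1 to compound 2 (0.76 log units; beyond the scatter), concerns the nitrile-bearing ring and does not bear on this change. Within the data shown here, no pair among the measured compounds shows a hydroxyazetidine at this carbonyl, so the direction cannot be read directly from the series; what is known is only that the substituent on this carbonyl moves the numbers by a large amount, as compound 1 and compound 3 show.

For compound 4 a step toward a lower number is therefore expected, in the region of a 3.7-fold lower number from compound 3 to compound 4 (0.56 log units; beyond the scatter), with wide uncertainty. The estimate for compound 4 is 3 nM, ranging from 0.8 nM to 12 nM.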

Compound 4, half-maximal inhibitory concentration: 7 nM
Compound 4: the middle estimate sits 2.3-fold (0.37 log units) below what was measured; the range from low to high includes it.
By their numbers in this assay, from the lowest: compound 1; then compounds 2, 4 and 3 (each within the scatter of the next, the first and the last beyond it).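

In this assay, 3-hydroxyazetidin-1-yl in place of piperazin-1-yl on the carbonyl carbon gives a 1.6-fold lower number from compound 3 to compound 4 (0.20 log units; within the scatter), so this read-out does not separate the two groups, although one is a four-membered ring and the other a six-membered ring. Morpholin-4-yl stands apart from both: 3-hydroxyazetidin-1-yl in its place gives a 10-fold higher number from compound 1 to compound 4 (1.00 log units; beyond the scatter), so the gap first seen with piperazin-1-yl also appears with a second group, and among these three groups only morpholin-4-yl gives a number in the range of compound 1. No supporting evidence is available to explain this grouping.

Open, as far as these compounds go, is whether a thiomorpholin-4-yl or a dimethylamino group on this carbonyl would fall with compound 1 or with compound 3 and compound 4. Also open, from the compounds shown here alone, is whether 1-cyanocyclobutyl in place of 1-cyanocyclopropyl has a step of similar size when 3-hydroxyazetidin-1-yl is on the carbonyl.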